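The source may report more compounds than this note shows. Statements on the series, on what has been measured and on what is new or still open speak of the compounds shown alone.

Of the compounds shown here, three have been measured in an assay on blood for inhibition of Indoleamine 2,3-dioxygenase 1 (Homo sapiens), read by mass spectrometry, with a stated time of 18 h; a higher number here means a weaker inhibitor, a lower number a stronger inhibitor. Compound 1 `CCC(c1nc2ncc(Cl)cc2[nH]1)[C@H]1CC[C@@H](c2ccnc3ccc(C(F)(F)F)cc32)CC1` gives 21 nM. Compound 3 `CCC(c1nc2ccc(Cl)cc2[nH]1)[C@H]1CC[C@@H](c2ccnc3ccc(F)cc32)CC1` gives 9 nM. Compound 2 `COCC(Nc1nnc(-c2ccc(OC)cc2)o1)[C@H]1CC[C@@H](c2ccnc3ccc(F)cc32)CC1` gives 31 nM, the highest of the three numbers: compound 1 sits within the usual scatter of it, while compound 3 lies beyond that scatter with a lower number. Among the compounds with values here, both compound 1 and compound 3 differ from compound 2 in more than one place, so no single step between measured compounds is available to guide the next change.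

Compound 4 `CCC(Nc1nnc(-c2ccc(OC)cc2)o1)[C@H]1CC[C@@H](c2ccnc3ccc(F)cc32)CC1` is not yet measured. It differs from compound 2 in one place: methyl in place of methoxy on a saturated chain carbon, two bonds along the chain from a nitrogen on an aromatic ring and a saturated ring carbon. Seen one bond further out, this is methoxymethyl giving way to ethyl, the same chain that compound 1 and compound 3 carry. Nothing measured shows this exact change on this core, so the expectation rests only on the spread of numbers among the three compounds, which is narrow. The step from compound 2 to compound 4 in this assay is expected to be small, toward a lower number if anything, and may well stay within the scatter: a 1.6-fold lower number from compound 2 to compound 4 (0.19 log units; within the scatter). Compound 4 is estimated at 20 nM, with a range from 8 nM to 50 nM.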

Compound 4, half-maximal inhibitory concentration: 16 nM
Beside the measured number, compound 4's estimate is 1.3-fold (0.10 log units) above it; measured number inside the range.
By their numbers in this assay, from the lowest: compounds 3, 4, 1 and 2 (each within the scatter of the next, the first and the last beyond it).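

In this assay, within the data shown here, methyl in place of methoxy on a saturated chain carbon gives a 1.9-fold lower number from compound 2 to compound 4 (0.29 log units; within the scatter) and so provides the first single change that can be read directly in this set. Methoxy carries 2 heavy atoms and 1 hydrogen-bond acceptor, while methyl carries 1 heavy atom and no acceptor, yet the two numbers cannot be told apart, so on this core the oxygen of the methoxymethyl chain is not required for a number in this range, and ethyl serves equally well at this position. No measurement at hand explains why the two groups read alike.

This one pair says little about how much room the position offers, as both groups are small and neither shows what a clearly different group would do to the number. A longer chain such as propyl, a ring such as cyclopropyl, or a hydroxymethyl or aminomethyl group at the same carbon would test whether this tolerance extends further or ends abruptly, and the compounds shown leave that question open.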